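Working notes: chloro to trifluoromethoxy on the fused ring

The source may hold more compounds than are shown below. What is called first, only, known or untested is meant among the compounds shown, and "the series" means these compounds.

Compound 2 `CCC(CC)(CC(=O)Nc1cccc(OCc2ccc3ccc(Cl)cc3n2)c1)C(=O)O`, tested in a functional assay on ileum (Cavia porcellus) for antagonist activity at cysteinyl leukotriene receptor (Homo sapiens) (on this read-out higher numbers stand for weaker inhibition and lower numbers for stronger inhibition), gives 0.8 nM and stands second highest of the three numbers in hand. Compound 1 `CCC(CC)(CC(=O)Nc1cccc(OCc2ccc3cc(F)c(F)cc3n2)c1)C(=O)O` gives 0.5 nM in this assay, a number within the scatter of compound 2; compound 3 `CCC(CC)(CC(=O)Nc1cccc(OCc2ccc3cc(C)c(C)cc3n2)c1)C(=O)O` gives 11 nM, which lies beyond the scatter from compound 2. Compound 4 `CCC(CC)(CC(=O)Nc1cccc(OCc2ccc3ccc(OC(F)(F)F)cc3n2)c1)C(=O)O` is not yet measured. It differs from compound 2 by trifluoromethoxy in place of chloro on an aromatic carbon. For the measured compounds named here, no measured pair shows this change, so its size is unknown; the only other substituent change in the set, the two methyl groups of compound 3, goes with a higher number. For compound 4 the step is expected to be a 2.5-fold higher number from compound 2 to compound 4 (0.40 log units; beyond the scatter), a small rise not certain to exceed the scatter. The estimate for compound 4 in this assay is 2 nM, with a range from 0.5 nM to 8 nM.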

Compound 4, half-maximal inhibitory concentration: 9 nM
The estimate for compound 4 lay 4.5-fold (0.65 log units) below the measured number; measured number outside the range, above it.
By their numbers in this assay, from the lowest: compounds 1 and 2 (each within the scatter of the next); then compounds 4 and 3 (each within the scatter of the next).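

In this assay, for the compounds shown here, trifluoromethoxy in place of chloro on this aromatic carbon gives an 11-fold higher number from compound 2 to compound 4 (1.05 log units; beyond the scatter) and is the first change that can be read at a single place. The step is large, so the number at this carbon depends strongly on which of these two groups it carries. Nothing on hand accounts for the size of the step.

Still open, from the compounds shown here alone, is where methoxy, a nitrile or an unsubstituted aromatic carbon would fall relative to chloro and trifluoromethoxy at this position.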